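A few compounds are considered here, and "the series" means these few. Any claim that something is new, unique, unknown or untested is made for them only; others in the source may bear on it.

Measured so far:
Compound 1 `Cc1nnc(SCC(=O)N/N=c2/scc(-c3ccc(F)cc3)n2-c2ccccc2)s1` — 383 ug/mL
Compound 2 `Cc1ccc(-c2cs/c(=N/NC(=O)CSc3nncn3C)n2-c2ccccc2)cc1` — 130 ug/mL
Compound 3 `Cn1cnnc1SCC(=O)N/N=c1/scc(-c2ccc(Br)cc2)n1-c1ccccc1` — 58.3 ug/mL

In an ADME assay on NIH3T3 cells (Mus musculus) for cytotoxicity, read by MTT assay, with a stated time of 24 h (a higher number here means a weaker inhibitor, a lower number a stronger inhibitor), compound 3 gives the lowest number of the three. Going by the values given here, its nearest neighbour is compound 2, which gives 130 ug/mL; the step of a 2.2-fold lower number from compound 2 to compound 3 (0.35 log units; beyond the scatter) is the only single-point change measured here. Among the compounds with values here, compound 1, the only member carrying the 5-methyl-1,3,4-thiadiazol-2-yl group, gives 383 ug/mL; no single step connects it to compound 3.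

Compound 4 `Cc1nnc(SCC(=O)N/N=c2/scc(-c3ccc(Br)cc3)n2-c2ccccc2)s1` differs from compound 3 by 5-methyl-1,3,4-thiadiazol-2-yl in place of 4-methyl-4H-1,2,4-triazol-3-yl on a sulfur. Within the data shown here, no measured step isolates this exchange, so the direction rests only on the values of compound 1 and compound 2, which differ in this ring and in the aryl substituent at once. Compound 4 is therefore expected to give a higher number than compound 3, the estimated step being a 2.9-fold higher number from compound 3 to compound 4 (0.46 log units; beyond the scatter), with wide uncertainty. For compound 4 in this assay the estimate is 170 ug/mL, with a range from 60 ug/mL to 450 ug/mL.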

Compound 4, half-maximal inhibitory concentration: 55 ug/mL
The estimate for compound 4 lay 3.1-fold (0.49 log units) above the measured number, and the stated range ends above it.
By their numbers in this assay, from the lowest: compounds 4 and 3 (each within the scatter of the next); then compound 2; then compound 1.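

On the sulfur, with bromo on the aromatic carbon, 5-methyl-1,3,4-thiadiazol-2-yl and 4-methyl-4H-1,2,4-triazol-3-yl cannot be told apart in this assay, with a 1.1-fold lower number from compound 3 to compound 4 (0.03 log units; within the scatter) as the printed step. Bromo in place of fluoro now gives a 7.0-fold lower number from compound 1 to compound 4 (0.84 log units; beyond the scatter) in the 5-methyl-1,3,4-thiadiazol-2-yl compounds, so an aromatic bromo step beyond the scatter appears with this ring as well as with the triazolyl ring, where bromo in place of methyl gives a 2.2-fold lower number from compound 2 to compound 3 (0.35 log units; beyond the scatter) in the same assay. No supporting evidence bears on the origin of either result.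

The compounds shown compare the two rings only with bromo on the aromatic carbon, so their equivalence with fluoro or methyl there remains open. Also open, on these data alone, is how a carboxylic acid or an amine-bearing chain on the sulfur would read in place of either ring.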